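A Nitrophenoxy Extension on Compound 2

The source may hold more compounds than are shown below. What is called first, only, known or untested is meant among the compounds shown, and "the series" means these compounds.

Compound 1 (`CC(C)=CCC1Cc2c(OC(=O)Nc3ccc(F)c(Cl)c3)cc(=O)n(CCCO)c2CC1(C)C`) gives 6800 nM
Compound 2 (`CCOc1cc(=O)n(CCCO)c2c1CC(C/C=C(\C)CCC=C(C)C)C(C)(C)C2`) gives 5800 nM

In a functional assay on PANC-1 cells (Homo sapiens) for inhibition, read by MTT assay, with a stated time of 24 h (on this read-out higher numbers stand for weaker inhibition and lower numbers for stronger inhibition), compound 2, at 5800 nM, lies within the usual scatter of compound 1, so the two stand level. Compound 3 (`CC(C)=CCC/C(C)=C/CC1Cc2c(OCCCOc3ccc([N+](=O)[O-])cc3)cc(=O)n(CCCO)c2CC1(C)C`) carries (4-nitrophenoxy)methyl in place of hydrogen on a saturated chain carbon, two bonds along the chain from an oxygen on an aromatic ring. Within the data shown here, no measured step covers this change. The expected step of a 1.5-fold lower number from compound 2 to compound 3 (0.16 log units; within the scatter) is small, toward stronger inhibition, and may not clear the scatter. Compound 3 is estimated at 4000 nM (expected range 1500 nM to 10000 nM).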

Compound 3, half-maximal inhibitory concentration: 6300 nM
Beside the measured number, compound 3's estimate is 1.6-fold (0.20 log units) below it, within the range that was stated.
By their numbers in this assay, from the lowest: compounds 2, 3 and 1 (each within the scatter of the next).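

In this assay the (4-nitrophenoxy)methyl on this saturated chain carbon gives a 1.1-fold higher number from compound 2 to compound 3 (0.04 log units; within the scatter) and so stands level with hydrogen. The earlier compounds shown here offered no step at this position; this one shows that it accepts a group with its own aromatic ring without a shift that clears the scatter. No evidence here explains this flat outcome.

From the compounds shown here alone, whether an amine or a carboxylic acid in place of the (4-nitrophenoxy)methyl would move the number beyond the scatter remains open. So does the effect of a longer chain.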